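The source may report more compounds than this note shows. Statements on the series, on what has been measured and on what is new or still open speak of the compounds shown alone.

Measured compounds: compound 1 `CC(O)(CSc1cccc(C(F)(F)F)c1)C(=O)Nc1cccc(S(F)(F)(F)(F)F)c1` gives 12700 nM; compound 2 `CC(O)(CSc1cc(C(F)(F)F)cc(C(F)(F)F)c1)C(=O)Nc1cccc(S(F)(F)(F)(F)F)c1` gives 4800 nM; compound 3 `CC(O)(COc1cccc(C(F)(F)F)c1)C(=O)Nc1cccc(S(F)(F)(F)(F)F)c1` gives 28800 nM, all in a functional assay on LNCaP cells (Homo sapiens) for antiproliferative activity, read by propidium iodide staining, with a stated time of 96 h; on this read-out higher numbers stand for weaker inhibition and lower numbers for stronger inhibition.

Within the sulfur-linked pair the single change trifluoromethyl in place of hydrogen on an aromatic carbon produced a 2.6-fold lower number from compound 1 to compound 2 (0.42 log units; beyond the scatter). Compound 3 carries a different core from compound 1; the difference between the two cores is not broken down here, and their two values show compound 3 with the higher number. Compound 4 `CC(O)(COc1cc(C(F)(F)F)cc(C(F)(F)F)c1)C(=O)Nc1cccc(S(F)(F)(F)(F)F)c1` is not yet measured in this assay. It carries the same change as the earlier pair, (trifluoromethyl in place of hydrogen on an aromatic carbon), with the place described in identical words. The step is expected to be a 2.6-fold lower number from compound 3 to compound 4 (0.42 log units; beyond the scatter), roughly matching the earlier one, because compound 2 showed a 2.6-fold lower number from compound 1 to compound 2 (0.42 log units; beyond the scatter) on the related core. Compound 4 is therefore estimated at 11000 nM, between 5000 nM and 25000 nM.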

Compound 4, half-maximal inhibitory concentration: 2800 nM
Compound 4: the middle estimate sits 3.9-fold (0.59 log units) above what was measured, and the stated range ends above it.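

In this assay, trifluoromethyl in place of hydrogen on an aromatic carbon gave a 10-fold lower number from compound 3 to compound 4 (1.01 log units; beyond the scatter), in the same direction as on the sulfur-linked core, but the size of the step did not carry over: the same change on two cores in this assay, a 2.6-fold lower number (0.42 log units; beyond the scatter) from compound 1 to compound 2 and a 10-fold lower number (1.01 log units; beyond the scatter) from compound 3 to compound 4, 3.9-fold (0.59 log units) apart, beyond the scatter of two such steps

The direction of the change therefore held on both cores shown, while its size has to be read core by core. Two pairs do not show which feature of the cores sets the gap, or how the change would behave on any further core.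

Going by these compounds, it remains open whether a nitrile or chlorine in the place of the added trifluoromethyl would give a step of either size. On these data alone, an amine nitrogen in place of the sulfur or oxygen linker is equally open.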